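A few compounds are considered here, and "the series" means these few. Any claim that something is new, unique, unknown or untested is made for them only; others in the source may bear on it.

Compounds measured in a functional assay on SNB-19 cells (Homo sapiens) for inhibition, read by sulforhodamine B assay, with a stated time of 48 h, tested at 0.1 uM; on this read-out higher numbers stand for a weaker effect at the one concentration tested and lower numbers for a stronger effect:

Compound 1, `O=C(Nc1cccc(-n2cc(-c3ccncc3)c(-c3cc(O)cc(Cl)c3)n2)c1)Nc1ccc(Cl)c(C(F)(F)F)c1`: 95%
Compound 2, `O=C(Nc1cccc(-n2cc(-c3ccncc3)c(-c3cc(O)cc(Cl)c3)n2)c1)Nc1ccc(Cl)c(Cl)c1`: 95%
Compound 3, `COc1cc(Cl)cc(-c2nn(-c3cccc(NC(=O)Nc4cc(C(F)(F)F)cc(C(F)(F)F)c4)c3)cc2-c2ccncc2)c1`: 87%

All three compounds share one core and differ only in the substituents on the outer aryl ring of the urea. Compound 3 gives the lowest of the three numbers in this assay, but its distance to compound 1 and to compound 2 lies within the usual scatter, so the three cannot be placed in any order on these data.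

For the measured compounds named here, the one step measured so far, no change at the digits printed from compound 1 to compound 2 (within the scatter), is the only comparison that bears on the unmeasured compound, and it concerns the same aryl ring of the urea. Going by the values given here, no measured pair removes a group altogether.

Compound 4, `COc1cc(Cl)cc(-c2nn(-c3cccc(NC(=O)Nc4cccc(C(F)(F)F)c4)c3)cc2-c2ccncc2)c1`, differs from compound 3 in one place:
hydrogen in place of trifluoromethyl on an aromatic carbon

Among the compounds with values here, since the one measured exchange at this ring left the read-out unchanged within the scatter, and no measured step shows a shift from taking a group away, compound 4 is expected to sit close to compound 3, with the step of a number 4 percentage points higher from compound 3 to compound 4 (within the scatter) expected to stay within the scatter. For compound 4 the estimate in this assay is 91%, with a range from 78% to 102%.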

Compound 4, a percentage reported as activity, at one concentration (the size of the read-out at that concentration, not a potency): 96%
Compound 4: middle estimate off by 5 percentage points, on the low side, within the range that was stated.
By their numbers in this assay, from the lowest: compounds 3, 1, 2 and 4 (each within the scatter of the next).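

For the compounds shown here, replacing a trifluoromethyl group with hydrogen on the outer aryl ring of the urea is the only measured step here that removes a group rather than exchanges one, and in this assay it gives a number 9 percentage points higher from compound 3 to compound 4 (within the scatter) on the shared core. Going by these compounds alone, the earlier pair showed only that an exchange at this ring, no change at the digits printed from compound 1 to compound 2 (within the scatter), left the read-out within the scatter; this step shows that taking away a trifluoromethyl group with its four heavy atoms also stays within the scatter at the one concentration tested. No measurement shown gives a reason for this result.

The compounds shown leave open whether replacing the trifluoromethyl group that remains in compound 4 with hydrogen, leaving this ring with no substituent, would move the read-out beyond the scatter. They also leave open whether a group of another kind at this place, such as an amine, a carboxylic acid or a longer alkyl chain, would separate from these values, and whether the compounds would differ from one another at other concentrations.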